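Chloro-to-hydrogen swap on a fused bicyclic core

The source may hold more compounds than are shown below. What is called first, only, known or untested is meant among the compounds shown, and "the series" means these compounds.

Measured so far:
compound 1, `ClCc1cccc(Cn2cnc3c(Cl)ncnc32)c1`: 2450 nM
compound 3, `ClCc1cccc(Cn2cnc3c(Cl)nc(Cl)nc32)c1`: 1820 nM
compound 2, `ClCc1ccc(Cn2cnc3nc(Cl)nc(Cl)c32)cc1`: "not determined" (no result reported)

In a functional assay on HOP-92 cells (Homo sapiens) for cytotoxicity, read by sulforhodamine B assay, with a stated time of 48 h (on this read-out lower numbers stand for stronger inhibition of growth and higher numbers for weaker inhibition of growth), compound 3 gives 1820 nM and compound 1 gives 2450 nM. The two differ in one place, (hydrogen in place of chloro on an aromatic carbon), and the step is a 1.3-fold higher number from compound 3 to compound 1 (0.13 log units; within the scatter). Compound 2 was carried through this assay with the outcome "not determined" (no result reported), so it gives no anchor of its own. The cores of compound 2 and compound 3 hold the same atoms joined differently; the difference between the two cores is not broken down here.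

Compound 4, `ClCc1ccc(Cn2cnc3ncnc(Cl)c32)cc1`, has not been run in this assay. It stands to compound 2 as compound 1 stands to compound 3: the change is hydrogen in place of chloro on an aromatic carbon, the same change, with the place described in the same words. The step made by that change is within the scatter, and in this assay the same size of step, close to none, is expected from compound 2 to compound 4. With no number for compound 2, the expectation rests on compound 1 at 2450 nM as the nearest measured analogue. Compound 4 is therefore estimated at 2500 nM in this assay, expected to fall between 800 nM and 8000 nM.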

Compound 4, concentration for 50% growth inhibition: 1170 nM
Estimate against measurement, compound 4: 2.1-fold (0.33 log units) above, and the stated range covers the measured number.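

In this assay, for the compounds shown here, compound 2 has no number to set against compound 4 at 1170 nM, so no step from compound 2 to compound 4 can be read. The compounds shown leave open what replacing chloro with hydrogen does on the core of compound 2. No supporting evidence bears on this result.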